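This account rests on a few compounds, and the source may have more. Where it says the series, first, only, none or still open, it means among the compounds named here.

Measured so far in a functional assay on MKN-45 cells (Homo sapiens) for cytotoxicity, read by MTT assay, with a stated time of 72 h; on this read-out lower numbers stand for stronger inhibition and higher numbers for weaker inhibition:

- compound 1 `CN(C)CCCNc1nc(-c2ccc(NC(=O)Nc3ccc(F)cc3)cc2)nc2c(Cl)c(Cl)sc12` gives 1120 nM
- compound 2 `CN(C)CCNc1nc(-c2ccc(NC(=O)Nc3ccc(F)cc3)cc2)nc2c(Cl)c(Cl)sc12` gives 1350 nM
- compound 3 `CCN(CC)CCCNc1nc(-c2ccc(NC(=O)Nc3ccccc3)cc2)nc2c(Cl)c(Cl)sc12` gives 1640 nM

Compound 3 has the highest of the three numbers, but its distance to compound 2 and to compound 1 stays within the usual scatter, so no order among the three can be read from these values.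

Compound 4 `CCN(CC)CCCNc1nc(-c2ccc(NC(=O)Nc3ccc(F)cc3)cc2)nc2c(Cl)c(Cl)sc12` is compound 3 with one change: fluoro in place of hydrogen on an aromatic carbon. Among the measured compounds shown here, the only step measured between two compounds that differ in a single place is a 1.2-fold higher number from compound 1 to compound 2 (0.08 log units; within the scatter), and it concerns the chain on the shared core, not the ring that carries the fluoro. Compound 1 and compound 3 both differ from each other in two places, the fluoro and the amine on the chain, so their two values show only that both sit within the scatter of each other and say nothing that can be pinned to the fluoro alone. For the measured compounds named here, no measured step therefore bears directly on the change from compound 3 to compound 4.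

With nothing in the data pointing either way, compound 4 is expected to give about 1400 nM in this assay, likely between 700 nM and 2800 nM. The step of a 1.2-fold lower number from compound 3 to compound 4 (0.07 log units; within the scatter) is thus estimated to lie within the scatter.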

Compound 4, half-maximal inhibitory concentration: 1700 nM
The estimate for compound 4 lay 1.2-fold (0.08 log units) below the measured number, within the range that was stated.
By their numbers in this assay, from the lowest: compounds 1, 2, 3 and 4 (each within the scatter of the next).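

In this assay, among the compounds shown here, replacing hydrogen with fluoro on the aromatic ring, which turns phenyl into 4-fluorophenyl, gives a 1.0-fold higher number from compound 3 to compound 4 (0.02 log units; within the scatter) and is the first direct look at this position, showing that this single atom leaves the number within the scatter in this pair. With the 4-fluorophenyl group held constant, diethylamino in place of dimethylamino gives a 1.5-fold higher number from compound 1 to compound 4 (0.18 log units; within the scatter) and (diethylamino)methyl in place of dimethylamino gives a 1.3-fold higher number from compound 2 to compound 4 (0.10 log units; within the scatter), so neither of these chain changes moves the number beyond the scatter either. No supporting data are available to explain these results.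

As far as these compounds go, a single fluoro para to a large group says little about the position as a whole, so it remains open whether chloro, methoxy or a carboxylic acid there would give a step beyond the scatter. At the other end of the molecule, a ring-shaped amine such as morpholine or piperidine, or a longer chain, could still show whether that part of the structure matters in this cell assay.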